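The source may hold more compounds than are shown below. What is called first, only, known or untested is meant among the compounds shown, and "the series" means these compounds.

Of the compounds shown here, two have been measured in an assay on CHO-K1 cells for displacement of a labelled ligand from melanin-concentrating hormone receptor 1 (Homo sapiens), read by scintillation proximity assay, with a stated time of 2 h; on this read-out lower numbers stand for stronger inhibition and higher numbers for weaker inhibition. Compound 1 `COCCC1(O)CCN(c2nc(C)c3cc(NC(=O)/C=C/c4ccc(Cl)cc4)ccc3n2)CC1` gives 245 nM in this assay, the higher of the two numbers. Compound 2 `COCC(=O)NC1CCN(c2nc(C)c3cc(NC(=O)/C=C/c4ccc(OC(F)(F)F)cc4)ccc3n2)CC1` gives 32 nM in this assay, a lower number that lies beyond the usual scatter of such measurements, so compound 2 is the stronger binder of the pair. Compound 2, however, differs from compound 1 in more than one place, so no single structural step can be read from these two values.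

The unmeasured compound 3 `Cc1nc(N2CCC(O)(C3CCC3)CC2)nc2ccc(NC(=O)/C=C/c3ccc(Cl)cc3)cc12` differs from compound 1 in one place only: cyclobutyl in place of 2-methoxyethyl on a saturated ring carbon. Among the compounds with values here, nothing among the measured compounds tests this kind of exchange, so the size and direction of its effect are unknown here. The step of a 1.2-fold lower number from compound 1 to compound 3 (0.09 log units; within the scatter) is therefore expected to stay within the scatter. Compound 3 is estimated at 200 nM in this assay, expected to fall between 60 nM and 700 nM.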

Compound 3, half-maximal inhibitory concentration: 206 nM
Estimate against measurement, compound 3: 1.0-fold (0.01 log units) below, and the stated range covers the measured number.
By their numbers in this assay, from the lowest: compound 2; then compounds 3 and 1 (each within the scatter of the next).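

On a saturated ring carbon, three ring bonds from the ring nitrogen, replacing 2-methoxyethyl with cyclobutyl gives a 1.2-fold lower number from compound 1 to compound 3 (0.08 log units; within the scatter) in this assay, so the two compounds cannot be told apart on this read-out. Within the data shown here, for this pair, then, losing the chain's oxygen, its hydrogen-bond acceptor, and closing the carbons into a four-membered ring leaves the number within the usual scatter, which the earlier compounds could not show. No measurement at hand explains this result.

On these data alone, whether an amine, a carboxylic acid or a longer chain on this carbon would behave the same way remains open. Compound 2 differs from the others in more than one place, so its steps to them cannot be read, and what separates its number from theirs stays unresolved.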